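The compounds below may be only part of what the source reports. "The series", "measured", "known", "first", "only" and "open" are said of these compounds alone.

In an in vivo ADME assay on the whole organism (strain CD1) for pharmacokinetics, with Mus musculus as the target, at a dose of 200 mg/kg by the oral route (on this read-out lower numbers stand for lower exposure and higher numbers for higher exposure at the dose given), two compounds with closely related structures have been measured so far. Compound 1 (`CCOC(=O)c1c(-c2cccc(OCC)c2)[nH]c2cc(OC)ccc2c1=O`) gives 2400 nM. Compound 2 (`CCOC(=O)c1c(-c2cccc(Cl)c2)[nH]c2cc(OC)c(F)cc2c1=O`) gives 66000 nM, the higher of the two numbers, and the gap between them lies beyond the usual scatter. The two compounds differ in more than one place, so their values cannot be tied to any single group.

Compound 3 (`CCOC(=O)c1c(-c2cccc(Br)c2)[nH]c2cc(OC)c(F)cc2c1=O`) departs from compound 2 in one place only: bromo in place of chloro on an aromatic carbon. Put simply, the 3-chlorophenyl group of compound 2 becomes a 3-bromophenyl group. Among the compounds with values here, no measured pair in this small set shows what this exchange does in this assay, so the data offer no direct precedent. The expectation is therefore anchored on compound 2 at 66000 nM, with no step beyond the scatter foreseen and no firm direction. The expected change is small, and the estimated step is a 1.3-fold lower number from compound 2 to compound 3 (0.12 log units; within the scatter). For compound 3, the estimated value is 50000 nM, with an expected range from 20000 nM to 120000 nM.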

Compound 3, maximal plasma concentration: 39000 nM
The estimate for compound 3 lay 1.3-fold (0.11 log units) above the measured number; measured number inside the range.
By their numbers in this assay, from the lowest: compound 1; then compounds 3 and 2 (each within the scatter of the next).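

In this assay, within the data shown here, the first pair in this set that differs in one place shows a 1.7-fold lower number from compound 2 to compound 3 (0.23 log units; within the scatter), so this exchange of the 3-chlorophenyl group for the 3-bromophenyl group can be read on its own, and compound 2 and compound 3 stand within the scatter of each other. At this place on the aromatic ring, meta to a large group, chloro and bromo therefore cannot be told apart by this read-out, and the high exposure seen with compound 2 is retained with bromo in the same position. Nothing measured on these compounds beyond this read-out bears on the result, so no explanation for it can be offered.

The compounds shown leave open what a group of another kind at this place, such as a nitrile, a methyl or an amine, would do to the read-out, since only two halogens can be compared here directly. They also leave open how far the ethoxy group and the fluoro group each account for the lower number of compound 1, and what a carboxylic acid in place of the ethyl ester would give.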